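Compound 2 to compound 3: piperidin-1-yl in place

This account rests on a few compounds, and the source may have more. Where it says the series, first, only, none or still open, it means among the compounds named here.

In a functional assay on MCF7 cells (Homo sapiens) for inhibition, read by sulforhodamine B assay (a higher number here means a weaker inhibitor, a lower number a stronger inhibitor), compound 2 `Cc1ccc(NC2=CC(=O)c3nc4n(c3C2=O)[C@H]2OC[C@@H](O)[C@H]2OC4)cc1` gives 1660 nM and compound 1 `Cc1ccc(NC2=CC(=O)c3nc4n(c3C2=O)[C@H]2OC[C@@H](O)[C@H]2OC4)cc1C` gives 2080 nM, so the two stand level within the scatter. Compound 3 `O=C1C=C(N2CCCCC2)C(=O)c2c1nc1n2[C@H]2OC[C@@H](O)[C@H]2OC1` carries piperidin-1-yl in place of (4-methylphenyl)amino on a double-bonded ring carbon. Among the measured compounds shown here, the only measured step, a 1.3-fold lower number from compound 1 to compound 2 (0.10 log units; within the scatter), exchanges a methyl for hydrogen on the aromatic ring and stays within the scatter, so it offers little guidance on replacing the whole group. The step expected in this assay is a 1.8-fold higher number from compound 2 to compound 3 (0.26 log units; within the scatter), a tentative estimate. Compound 3 is estimated at 3000 nM, with an expected range of 900 nM to 10000 nM.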

Compound 3, half-maximal inhibitory concentration: > 8000 nM
Compound 3 gave a limit, no number; the forecaster's own chance of this, stated with the estimate: 3%; at least 2.6-fold (0.42 log units) between middle value and limit.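

Unlike the exchange of methyl for hydrogen on the aromatic ring, replacing the arylamino group on this double-bonded ring carbon moves the result in this assay beyond the scatter: an at least 4.8-fold higher number from compound 2 to compound 3 (0.68 log units; beyond the scatter), and an at least 3.8-fold higher number from compound 1 to compound 3 (0.58 log units; beyond the scatter). Compound 3 gives a limit, not a number: the limit of > 8000 nM in this assay, at which 1 of the 3 values shown sits.

This change swaps the aromatic ring for a non-aromatic one and removes the hydrogen-bond donor in a single step, and the compounds shown do not separate the two. A cyclohexylamino group, or a methyl(phenyl)amino group, at this position would pull them apart.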